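The compounds below may be only part of what the source reports. "The series", "measured", "known", "first", "only" and "open" are said of these compounds alone.

Measured so far:
- compound 1 `CCCCCCCCCCSc1ncnc2c1ncn2C1CCCCC1` — in an ADME assay on Vero cells (Chlorocebus sabaeus) for cytotoxicity; on this read-out higher numbers stand for lower toxicity in this test and lower numbers for higher toxicity in this test: "not determined" (no result reported)
- compound 2 `CCCCCCCCCCSc1ncnc2c1ncn2CC(=O)OCC` — in this assay: > 62.5 ug/mL

Compound 2 gives no single number in this assay; its value > 62.5 ug/mL is a limit of the assay, the limit (the limit of > 62.5 ug/mL in this assay, at which 1 of the 2 values shown sits). Compound 3 `CCCCCCCCCCSc1ncnc2c1ncn2CC(=O)OC(C)(C)C` is the next compound to test. It differs from compound 2 by tert-butyl in place of ethyl on an oxygen next to a carbonyl group. Among the compounds with values here, with no measured step between the two known compounds, the expected step that the limit leaves unreadable from compound 2 to compound 3 is none beyond the usual scatter. For compound 3 the expected value is therefore 80 ug/mL, with a range from 40 ug/mL to 200 ug/mL.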

Compound 3, half-maximal cytotoxic concentration: > 10 ug/mL
Compound 3 ended at the assay's limit (the forecaster's own chance of this, stated with the estimate: 75%); the middle value is on the limit's open side.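

No step can be read from compound 2 to compound 3 in this assay: each gives only a limit, not a number. From the compounds shown here alone, whether tert-butyl in place of ethyl changes the cytotoxicity at all remains open.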